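The source may report more compounds than this note shows. Statements on the series, on what has been measured and on what is new or still open speak of the compounds shown alone.

In a functional assay on HEK293 cells for agonist activity at Free fatty acid receptor 1 (Homo sapiens), read by HTRF and inositol phosphate accumulation, with a stated time of 60 min (a higher number here means that more compound is needed for the effect, a lower number that less compound is needed), compound 1 `O=C(O)CC[C@H]1CCc2cc(-c3cc(OC4CCC4)ccc3F)ccc2O1` gives 3600 nM. Compound 2 `O=C(O)CC[C@H]1CCc2cc(-c3cc(OC4CCC4)cc(Cl)c3F)ccc2O1` returns only the assay limit of > 10000 nM. Compound 3 `COc1cc(OC2CCC2)cc(-c2ccc3c(c2)CC[C@H]([C@@H]2C[C@H]2C(=O)O)O3)c1F` likewise returns only the assay limit of > 10000 nM, so it stands where (the limit of > 10000 nM in this assay, at which 2 of the 3 values shown sit). Compound 4 `COc1cc(OC2CCC2)cc(-c2ccc3c(c2)CC[C@H](CCC(=O)O)O3)c1F` differs from compound 3 by 2-carboxyethyl in place of 2-carboxycyclopropyl on a saturated ring carbon. Within the data shown here, no measured step covers this change; the only measured step, an at least 2.7-fold higher number from compound 1 to compound 2 (0.44 log units; beyond the scatter), concerns chloro for hydrogen on an aromatic carbon and carried the value past the limit. Compound 4 also bears an added group on an aromatic carbon, so little gain is expected. The estimated step of an at least 1.1-fold lower number from compound 3 to compound 4 (0.04 log units; that floor lies within the scatter) is expected to stay within the scatter. Compound 4 is therefore expected near 9000 nM, between 3000 nM and 30000 nM.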

Compound 4, half-maximal effective concentration: > 10000 nM
Compound 4: a limit, no number; the forecaster's own chance of this, stated with the estimate: 50%; middle value at least 1.1-fold (0.04 log units) from the limit.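

In this assay, methoxy on this aromatic carbon, with an at least 2.7-fold higher number from compound 1 to compound 4 (0.44 log units; beyond the scatter), behaves as chloro did in compound 2, so a second, different group here also ends at a limit. The steps to compound 4 from compound 2 and from compound 3 cannot be read, as both ends of each are limits, and the 2-carboxyethyl chain brings no measurable value back. Most of the set now rests at one limit: the limit of > 10000 nM in this assay, at which 3 of the 4 values shown sit.

On these data alone, whether a nitrile or a hydroxyl on this carbon would hold near compound 1 at 3600 nM stays open. So does any difference between the two acid side chains, which would need a core that reads below the limit.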